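This account rests on a few compounds, and the source may have more. Where it says the series, first, only, none or still open, it means among the compounds named here.

The measured compounds and their values:

Compound 1, `CC(=O)c1ccc2[nH]c(-c3ccccc3)nc2c1`. In an ADME assay on BHK-21 cells (Mesocricetus auratus) for cytotoxicity, read by MTT assay (a higher number here means that more compound is tolerated, a lower number that less compound is tolerated), compound 1 gives only a limit, > 100000 nM.
Compound 2, `CC(=O)c1ccc2[nH]c(-c3ccc(Cl)cc3)nc2c1`. In this assay compound 2 gives only a limit, > 100000 nM.
Compound 3, `C/C(=N\NC(N)=O)c1ccc2c(c1)nc(-c1ccccc1)n2C1CCCCC1`. In this assay compound 3 gives only a limit, > 100000 nM.

Compound 1 and compound 2 differ in one place, (chloro in place of hydrogen on an aromatic carbon). The corresponding step, a step that the two limits leave unreadable from compound 1 to compound 2, cannot be sized, since (the limit of > 100000 nM in this assay, at which 3 of the 3 values shown sit). Compound 3 carries a different core from compound 1; the difference between the two cores is not broken down here. Compound 4, `C/C(=N\NC(N)=O)c1ccc2c(c1)nc(-c1ccc(Cl)cc1)n2C1CCCCC1`, has not yet been measured in this assay. It stands to compound 3 as compound 2 stands to compound 1: chloro in place of hydrogen on an aromatic carbon. The place of the change is described in the same words for both pairs, so it is the same change, occurring twice among the compounds shown.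

Among the measured compounds shown here, every value so far in this assay sits at a limit, so no step has yet been read as a number. The expectation for compound 4 rests on compound 3, whose value is > 100000 nM, and on the fact that the same change on compound 1 gave compound 2 a value of > 100000 nM, also a limit. The step expected is a step that the limit leaves unreadable from compound 3 to compound 4, which is to say no readable movement. Compound 4 is therefore estimated at 150000 nM, with a range from 60000 nM to 400000 nM, and most likely this assay will again report only a limit for compound 4.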

Compound 4, half-maximal cytotoxic concentration: > 100000 nM
Compound 4 gave a limit, no number; the forecaster's own chance of this, stated with the estimate: 85%; the middle value does not contradict the limit.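

In this assay compound 4 gives > 100000 nM as a limit and not a number. The step from compound 3 to compound 4 therefore cannot be read, and neither compound pair offers a size for it: the limit of > 100000 nM in this assay, at which 4 of the 4 values shown sit. The compounds shown leave open how far, if at all, going from phenyl to 4-chlorophenyl moves the tolerated concentration on either core.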